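A few compounds are considered here, and "the series" means these few. Any claim that something is new, unique, unknown or untested is made for them only; others in the source may bear on it.

Compound 1 `NC(=O)c1c(NC(=O)c2ccccc2Cl)sc2c1CCN(Cc1ccc([N+](=O)[O-])cc1)C2` gives 31500 nM in a functional assay on MKN-74 cells (Homo sapiens) for antiproliferative activity, with a stated time of 24 h; a lower number here means a stronger inhibitor, a higher number a weaker inhibitor.
Compound 3 `NC(=O)c1c(NC(=O)c2ccccc2F)sc2c1CCN(Cc1cccc(Cl)c1)C2` gives 23300 nM in this assay.
Compound 2 `NC(=O)c1c(NC(=O)c2ccc(C(F)(F)F)cc2)sc2c1CCN(Cc1ccc(Cl)cc1)C2` is recorded only as a limit, > 50000 nM, in this assay.

Among the two compounds with a number, compound 1 has the higher value, but compound 3 sits close to it, and the gap between them is within the scatter, so no order can be read from the pair. The value for compound 2 is a limit of the assay and not a number (the limit of > 50000 nM in this assay, at which 1 of the 3 values shown sits), so it adds no further point of comparison.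

Compound 4 `CSc1ccccc1NC(=S)N1CCc2c(sc(NC(=O)c3ccccc3Cl)c2C(N)=O)C1` keeps the shared core of compound 1 and changes one place: a group of 11 heavy atoms (8 carbon, 1 nitrogen, 2 sulfur; one six-membered aromatic ring of carbon only) in place of a group of 10 heavy atoms (7 carbon, 1 nitrogen, 2 oxygen; one six-membered aromatic ring of carbon only), on an amine nitrogen in a ring. The newly entering group brings one hydrogen-bond donor where the leaving group had none.

Among the measured compounds shown here, no measured pair in this set differs in just one place, so the size of this kind of step has not been seen here. All three measured compounds are weak in this assay, and nothing in the data points to a direction for the change. Compound 4 is therefore expected to land near compound 1, with a step of a 1.1-fold lower number from compound 1 to compound 4 (0.05 log units; within the scatter) that is small and uncertain in direction. The estimate for compound 4 is 28000 nM, with a likely range from 8000 nM to 50000 nM.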

Compound 4, half-maximal inhibitory concentration: 13800 nM
The estimate for compound 4 lay 2.0-fold (0.31 log units) above the measured number; the range from low to high includes it.
By their numbers in this assay, from the lowest: compounds 4, 3 and 1 (each within the scatter of the next, the first and the last beyond it). At a limit, above all of these: compound 2.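

Among the compounds shown here, at the amine nitrogen in the ring, this assay now shows for the first time what a single change does: replacing 4-nitrobenzyl with the sulfur-containing group that has no common name gives a 2.3-fold lower number from compound 1 to compound 4 (0.36 log units; beyond the scatter), a modest step beyond the scatter. The position therefore accepts an entering group that brings a hydrogen-bond donor where the leaving group had none, and the number does not rise, although the change also swaps the oxygen atoms for sulfur and alters how the aromatic ring is attached, so no single feature can be credited with the step. Nothing measured here gives a cause for this step.

The compounds shown leave open whether the hydrogen-bond donor or the sulfur atoms matter more, and whether a plain benzyl group or a chain ending in a carboxylic acid on this nitrogen would give a number closer to that of compound 1 or that of compound 4. They also leave open whether the same change would give a step of similar size with a different group on the amide.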